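Phenyl to 3,4-dichlorophenyl on the shared core

A few compounds are considered here, and "the series" means these few. Any claim that something is new, unique, unknown or untested is made for them only; others in the source may bear on it.

Measured so far in a functional assay on SEM cells (Homo sapiens) for cytotoxicity, with a stated time of 72 h (on this read-out higher numbers stand for an effect only at larger amounts of compound and lower numbers for an effect already at smaller amounts), on two compounds:
- compound 1 `C=C[C@@](C)(/C=C/c1ccc(Nc2cc(F)cc(F)c2)cc1)CCC=C(C)C` gives > 36600 nM
- compound 2 `C=C[C@@](C)(/C=C/c1ccc(-c2ccccc2)cc1)CCC=C(C)C` gives > 36600 nM

Compound 2 stands at > 36600 nM as a limit of the assay, not a number. The evidence so far is the limit of > 36600 nM in this assay, at which 2 of the 2 values shown sit, and nothing more. Compound 3 `C=C[C@@](C)(/C=C/c1ccc(-c2ccc(Cl)c(Cl)c2)cc1)CCC=C(C)C` carries 3,4-dichlorophenyl in place of phenyl, para to a large group, and 3,4-dichlorophenyl in place of phenyl on an aromatic carbon counts that change. Among the measured compounds shown here, the only measured step is a step that the two limits leave unreadable from compound 1 to compound 2 and offers no size to carry over. In this assay no step beyond the scatter is expected, and another limit is likely. The expected step is a step that the limit leaves unreadable from compound 2 to compound 3 as estimated. Compound 3 is estimated at 40000 nM with 20000 nM to 80000 nM as its range.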

Compound 3, half-maximal effective concentration: > 36600 nM
Compound 3: a limit, no number; the forecaster's own chance of this, stated with the estimate: 80%; the middle value is on the limit's open side.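

Compound 3 gives only a limit, not a number, as do compound 1 and compound 2, so no step among these three can be read. The compounds shown leave open whether any change on the shared core would yield a measurable value.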